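From compound 3 to compound 4: nitro enters

A few compounds are considered here, and "the series" means these few. Any claim that something is new, unique, unknown or untested is made for them only; others in the source may bear on it.

In a functional assay on RAW264.7 cells (Mus musculus) for inhibition, read by Griess assay, with stated times of 3 h and 24 h (on this read-out lower numbers stand for stronger inhibition and higher numbers for weaker inhibition), compound 3 `C=C1CCC2[C@](C)(CO)[C@H](O)CC[C@@]2(C)[C@@H]1CCOc1ccc(-c2cc(=O)c3cc(C)ccc3o2)cc1` gives > 100000 nM, which is a limit and not a number. Compound 3 thus stands at the limit of > 100000 nM in this assay, at which 1 of the 3 values shown sits. Compound 4 `C=C1CCC2[C@](C)(CO)[C@H](O)CC[C@@]2(C)[C@@H]1CCOc1ccc([N+](=O)[O-])cc1` differs from it in one place: a group of 3 heavy atoms (1 nitrogen, 2 oxygen; no ring) in place of a group of 12 heavy atoms (10 carbon, 2 oxygen; one six-membered aromatic ring of carbon only, one six-membered aromatic ring with 1 hetero atom), on an aromatic carbon, on an aromatic carbon of a six-membered aromatic ring of carbon only. In this assay compound 1 `C=C1CCC2[C@](C)(CO)[C@H](O)CC[C@@]2(C)[C@@H]1CCOc1ccc(Oc2ccccc2)cc1` gives 12800 nM, and compound 2 `C=C1CCC2[C@](C)(CO)[C@H](O)CC[C@@]2(C)[C@@H]1CCOc1ccc(C(C)(C)C)cc1` gives 35800 nM. Three measured steps change this same place: an at least 7.8-fold higher number from compound 1 to compound 3 (0.89 log units; beyond the scatter), an at least 2.7-fold higher number from compound 2 to compound 3 (0.44 log units; beyond the scatter) and a 2.8-fold higher number from compound 1 to compound 2 (0.45 log units; beyond the scatter). The first two suggest that losing the large group of compound 3 should lower the number modestly. The expected step is an at least 2.8-fold lower number from compound 3 to compound 4 (0.45 log units; beyond the scatter), and a reading at the limit remains possible. For compound 4 the estimate is 35000 nM, with an expected range of 12000 nM to 100000 nM.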

Compound 4, half-maximal inhibitory concentration: 3380 nM
Compound 4: middle estimate off by 10-fold (1.02 log units), on the high side; measured number below the stated range.
By their numbers in this assay, from the lowest: compound 4; then compound 1; then compound 2. At a limit, above all of these: compound 3.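

Within this assay, this position does not need a large group for a low number: nitro, with only 3 heavy atoms, gives a 3.8-fold lower number from compound 1 to compound 4 (0.58 log units; beyond the scatter) and an 11-fold lower number from compound 2 to compound 4 (1.02 log units; beyond the scatter). Among the three measured numbers, the group with the fewest heavy atoms thus gives the lowest value. Compound 3 is a limit and not a number, so this change reads only as an at least 29-fold lower number from compound 3 to compound 4 (1.47 log units; beyond the scatter): the limit of > 100000 nM in this assay, at which 1 of the 4 values shown sits.

The compounds shown leave open whether the low number is specific to nitro or extends to other small groups. A nitrile, an amine or a carboxylic acid at this position would test that.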